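Removing the Ring Hydroxy Group: Compound 1 to Compound 3

The source may report more compounds than this note shows. Statements on the series, on what has been measured and on what is new or still open speak of the compounds shown alone.

Compound 1 `Cc1ccccc1S(=O)(=O)N1CC(O)C[C@H]1C(=O)Nc1ccc(C(=O)O)cc1` was tested in a functional assay on the whole organism for inhibition, with Rattus norvegicus as the target, read by paw edema, with a stated time of 1 h, at a dose of 100 mg/kg by the oral route (a higher number here means more inhibition at the dose given (going by the name of the read-out), a lower number less inhibition), where compound 1 gives 21.2%. For the measured compounds named here, its only measured relative is compound 2 `O=C(O)c1ccc(NC(=O)[C@@H]2CC(O)CN2S(=O)(=O)c2ccccc2)cc1`, which carries hydrogen in place of methyl on an aromatic carbon; in this assay compound 2 gives 24.7%. Going by the values given here, the single measured step, a number 3.5 percentage points higher from compound 1 to compound 2 (within the scatter), lies within the scatter, so compound 1 and compound 2 sit together and their two numbers cannot be told apart.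

The unmeasured compound 3 `Cc1ccccc1S(=O)(=O)N1CCC[C@H]1C(=O)Nc1ccc(C(=O)O)cc1` differs from compound 1 in one place: hydrogen in place of hydroxy on a saturated ring carbon. Among the compounds with values here, no measured step touches this part of the shared core. Within the data shown here, the one step available swaps a group on an aromatic carbon, not on the saturated ring carbon of the five-membered non-aromatic ring, and that step was itself within the scatter. Nothing in the data points in either direction for the loss of the hydroxy group. The expected step of a number 0.2 percentage points lower from compound 1 to compound 3 (within the scatter) is therefore set at about zero, with a wide band around it. In this assay compound 3 is estimated at 21%, with a range from 6% to 36%.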

Compound 3, a percentage reported as inhibition, in the whole organism at one dose (the size of the read-out at that dose, not a potency): 39.4%
Estimate against measurement, compound 3: 18.4 percentage points below; the whole stated range lies below it.
By their numbers in this assay, from the lowest: compounds 1 and 2 (each within the scatter of the next); then compound 3.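

In this assay, the saturated ring carbon two ring bonds from the ring nitrogen proves sensitive to change: hydrogen in place of hydroxy gives a number 18.2 percentage points higher from compound 1 to compound 3 (beyond the scatter). For the compounds shown here, this differs from the only earlier comparison, where the change on an aromatic carbon gave a number 3.5 percentage points higher from compound 1 to compound 2 (within the scatter), so this ring carbon is the one place in the set where a single change clearly moves the number, though the read-out gives the size of the effect at one dose and not a potency. The data offer no measurement that would explain the gain in inhibition on losing the hydroxy group.

Only hydroxy and hydrogen are shown on this ring carbon, so it remains open whether a methoxy group, a fluorine atom or an amine there would give a number closer to that of compound 3 or to that of compound 1. On these data alone, it is also open whether the same loss of hydroxy from compound 2, which lacks the methyl group on the aromatic ring, would bring a step of similar size.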